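Compound 3 to compound 4: chloro gives way to methoxy

This account rests on a few compounds, and the source may have more. Where it says the series, first, only, none or still open, it means among the compounds named here.

Values in an ADME assay on HEp-2 cells (Homo sapiens) for cytotoxicity; a higher number here means that more compound is tolerated, a lower number that less compound is tolerated:
- compound 1 `Cc1ccc(NC(=O)[C@@H]2CCCN2S(=O)(=O)c2cccc3cccnc23)cc1`: 31700 nM
- compound 2 `O=C(Nc1ccc(Cl)cc1Cl)[C@@H]1CCCN1S(=O)(=O)c1cccc2cccnc12`: > 50000 nM (a limit of the assay)
- compound 3 `Cc1ccc(Cl)cc1NC(=O)[C@@H]1CCCN1S(=O)(=O)c1cccc2cccnc12`: 10000 nM

The value for compound 2 is a limit and not a number. Of the two exact values, compound 3 has the lower at 10000 nM, and compound 1 gives 31700 nM. Compound 4 `COc1ccc(C)c(NC(=O)[C@@H]2CCCN2S(=O)(=O)c2cccc3cccnc23)c1` has methoxy in place of chloro on an aromatic carbon, para to a methyl group: methoxy in place of chloro on an aromatic carbon. Going by the values given here, no measured step makes this exchange. The closest evidence comes from changing the substituted phenyl on the amide-type nitrogen, which gave a 3.2-fold lower number from compound 1 to compound 3 (0.50 log units; beyond the scatter) and an at least 5.0-fold lower number from compound 2 to compound 3 (0.69 log units; beyond the scatter). Another such change gave an at least 1.5-fold higher number from compound 1 to compound 2 (0.19 log units; that floor lies within the scatter). Changes at this group can therefore move the number modestly or more, and compound 3 at 10000 nM lies at the low end, so a modest rise is expected, though the direction is uncertain. The expected change is a 1.8-fold higher number from compound 3 to compound 4 (0.26 log units; within the scatter). The estimate for compound 4 is 18000 nM, with an expected range of 6000 nM to 45000 nM.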

Compound 4, half-maximal cytotoxic concentration: 44200 nM
Compound 4: middle estimate off by 2.5-fold (0.39 log units), on the low side, and the stated range covers the measured number.
By their numbers in this assay, from the lowest: compound 3; then compounds 1 and 4 (each within the scatter of the next). At a limit, above all of these: compound 2.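

Methoxy in place of chloro, para to a methyl group, gives a 4.4-fold higher number from compound 3 to compound 4 (0.65 log units; beyond the scatter) in this assay, so this single exchange at this position moves the number beyond the scatter. The 5-methoxy-2-methylphenyl group in place of the 4-methylphenyl group gives a 1.4-fold higher number from compound 1 to compound 4 (0.14 log units; within the scatter), whereas the 5-chloro-2-methylphenyl group in place of the 4-methylphenyl group gives a 3.2-fold lower number from compound 1 to compound 3 (0.50 log units; beyond the scatter). The value of compound 2 is a limit and not a number: the limit of > 50000 nM in this assay, at which 1 of the 4 values shown sits. The 5-methoxy-2-methylphenyl group in place of the 2,4-dichlorophenyl group gives an at least 1.1-fold lower number from compound 2 to compound 4 (0.05 log units; that floor lies within the scatter), and no order can be drawn from this step.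

Going by these compounds, what an amine, a hydroxyl or a longer alkoxy chain would do at this position stays open. Also open, on these data alone, is whether the same exchange would give a similar step with the other groups on the amide-type nitrogen.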